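Cyclohexyl for sec-butyl on the amine nitrogen

The source may report more compounds than this note shows. Statements on the series, on what has been measured and on what is new or still open speak of the compounds shown alone.

Compound 1 `CCC(C)NC(=C\C(=O)/C=C/c1ccc(O)c(OC)c1)/C=C/c1ccc(O)c(OC)c1` and compound 2 `COc1cc(/C=C/C(=O)/C=C(/C=C/c2ccc(O)c(OC)c2)NC2CCCCC2)ccc1O` share one core; compound 3 `CCC(C)NC(=C\C(=O)/C=C/c1ccc(O)cc1)/C=C/c1ccc(O)cc1` and the unmeasured compound 4 `O=C(/C=C(/C=C/c1ccc(O)cc1)NC1CCCCC1)/C=C/c1ccc(O)cc1` share another. How the core of compound 1 differs from that of compound 3 is not broken down here.

In a functional assay on Caco-2 cells (Homo sapiens) for inhibition, read by MTT assay, with a stated time of 72 h (on this read-out higher numbers stand for weaker inhibition and lower numbers for stronger inhibition), compound 1 gives > 25000 nM, a limit of the assay rather than a number. Compound 2 likewise gives > 25000 nM, also a limit. Compound 3 gives 9400 nM in this assay. The change cyclohexyl in place of sec-butyl on an amine nitrogen therefore made a step that the two limits leave unreadable from compound 1 to compound 2; the two values sit at the limit of > 25000 nM in this assay, at which 2 of the 3 values shown sit, so no size can be read from it.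

The same change, (cyclohexyl in place of sec-butyl on an amine nitrogen), is now applied to compound 3. With nothing readable from compound 1 and compound 2, a step of about a 1.1-fold higher number from compound 3 to compound 4 (0.03 log units; within the scatter) is expected, resting only on compound 3 at 9400 nM. Compound 4 is estimated at 10000 nM, expected between 4000 nM and 25000 nM.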

Compound 4, half-maximal inhibitory concentration: 7800 nM
Compound 4: the middle estimate sits 1.3-fold (0.11 log units) above what was measured, within the range that was stated.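

In this assay, cyclohexyl in place of sec-butyl on an amine nitrogen gives a 1.2-fold lower number from compound 3 to compound 4 (0.08 log units; within the scatter), so the two groups cannot be told apart on this core. For the compounds shown here, the step from compound 1 to compound 2 cannot be read, since both compounds sit at a limit of the assay: the limit of > 25000 nM in this assay, at which 2 of the 4 values shown sit. Carrying the change from one core to the other therefore remains untested, as only one core gives a readable step, and that step cannot show whether the two cores respond alike.

The compounds shown leave open whether a different group on the amine nitrogen, such as a benzyl group or a longer straight chain, would give a step beyond the scatter. They also leave open whether such a group would bring the core of compound 1 to a readable value.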